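Triazolyl ureas: thiophene-methyl to pyridine-methyl swap

This account rests on a few compounds, and the source may have more. Where it says the series, first, only, none or still open, it means among the compounds named here.

Measured so far in a functional assay on MCF7 cells (Homo sapiens) for cytotoxicity, read by MTT assay, with a stated time of 48 h; a higher number here means a weaker inhibitor, a lower number a stronger inhibitor:
- Compound 1 `O=C(NCc1ccccc1)N(Cc1ccccn1)n1cnnc1` sits at the assay limit, > 50000 nM.
- Compound 2 `Cc1ccc(NC(=O)N(Cc2ccccn2)n2cnnc2)cc1` gives 38900 nM.
- Compound 3 `Cc1ccsc1CN(C(=O)Nc1ccccc1)n1cnnc1` sits at the assay limit, > 50000 nM.

Compound 3 thus stands at the limit and not at a number; with the limit of > 50000 nM in this assay, at which 2 of the 3 values shown sit, most of the series is there. For the measured compounds named here, the only step with two numbers is an at least 1.2-fold lower number from compound 1 to compound 2 (0.10 log units; that floor lies within the scatter), and even its floor lies within the scatter. Compound 4 `O=C(Nc1ccccc1)N(Cc1ccccn1)n1cnnc1` differs from compound 3 by pyridin-2-yl in place of 3-methylthiophen-2-yl on a saturated chain carbon bound to an amide-type nitrogen. Going by the values given here, no measured step touches that position: the step from compound 1 to compound 2 alters the urea substituent, not the chain carbon on the amide-type nitrogen. Compound 1 already carries the (pyridin-2-yl)methyl group and sits at the limit. For compound 4 no step beyond the scatter is expected, so an at least 1.0-fold lower number from compound 3 to compound 4 (0.01 log units; that floor lies within the scatter) is taken as essentially flat. Compound 4 is therefore estimated at 48000 nM, between 20000 nM and 100000 nM, with a fair chance that only a limit is reported.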

Compound 4, half-maximal inhibitory concentration: > 50000 nM
Compound 4: a limit, no number; the forecaster's own chance of this, stated with the estimate: 60%; middle value at least 1.0-fold (0.01 log units) from the limit.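

In this assay compound 4 gives > 50000 nM, which is a limit of the assay and not a number. For the compounds shown here, the steps to compound 4 from compound 3 and from compound 1 join two limits and cannot be read, so pyridin-2-yl in place of 3-methylthiophen-2-yl on a saturated chain carbon bound to an amide-type nitrogen gets no size, and the series stays largely at one ceiling: the limit of > 50000 nM in this assay, at which 3 of the 4 values shown sit. The only readable new step is an at least 1.2-fold higher number from compound 2 to compound 4 (0.10 log units; that floor lies within the scatter), with hydrogen in place of methyl on an aromatic carbon.

Compound 2 remains the only compound shown with a number, so the effect of this change at the chain carbon stays open. Also open, on these data alone, is how an amine or a carboxylic acid in place of that methyl on an aromatic carbon would read.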